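The compounds below may be only part of what the source reports. "The series", "measured", "known", "first", "only" and "open" are said of these compounds alone.

Of the compounds shown here, two built on the shared core have been measured. Compound 1 `O=c1c(-c2ccc(O)cc2)coc2cc(CC3OC(CO)C(O)C(O)C3O)ccc12` and compound 2 `O=c1c(-c2ccc(O)cc2)coc2cc(OCCCCBr)ccc12` differ in the group carried by the oxygen on an aromatic ring. Among the measured compounds shown here, in a functional assay on mitochondria (Cricetulus griseus) for inhibition of Monoamine oxidase (Homo sapiens), tested at 0.9 uM (on this read-out higher numbers stand for a stronger effect at the one concentration tested and lower numbers for a weaker effect), compound 1 gives 0%, while compound 2 gives 55.3%, the higher of the two numbers; its only neighbour, compound 1, lies lower by a gap that exceeds the usual scatter of repeated measurements. For the measured compounds named here, no pair of measured compounds differs in a single place, so compound 2 is the sole anchor for compound 3 `C=CCOc1ccc2c(=O)c(-c3ccc(O)cc3)coc2c1`, which has not yet been measured. Compound 3 differs from compound 2 in one place (vinyl in place of 3-bromopropyl on a saturated chain carbon bound to an oxygen on an aromatic ring). Going by the values given here, compound 1 shows only that a very different group at that oxygen sits far lower. In this assay the expected step is a loss of moderate size, a number 25.3 percentage points lower from compound 2 to compound 3 (beyond the scatter). Compound 3 is therefore estimated at 30%, within a range from 5% to 60%.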

Compound 3, a percentage reported as inhibition, at one concentration (the size of the read-out at that concentration, not a potency): 68.8%
Compound 3: middle estimate off by 38.8 percentage points, on the low side; the measured number lies above the stated range.
By their numbers in this assay, from the lowest: compound 1; then compound 2; then compound 3.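

In this assay, among the compounds shown here, putting vinyl in place of 3-bromopropyl on a saturated chain carbon bound to an oxygen on an aromatic ring gives a number 13.5 percentage points higher from compound 2 to compound 3 (beyond the scatter), the first step that can be read at this position. It shows that the read-out there responds to a change between two open chains with no ring, and that the bromine is not required for the read-out to stay high: compound 3 carries none. Nothing in the data accounts for this step.

Going by these compounds, whether the rise belongs to the double bond, the missing bromine or the shorter chain stays open, as the change from 4-bromobutyl to allyl alters all three at once. On these data alone, how a plain propyl chain, a longer chain or a chain ending in an amine would read on this oxygen also remains unknown.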